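From Methyl to Diallylamino on an Inactive Compound

The source may hold more compounds than are shown below. What is called first, only, known or untested is meant among the compounds shown, and "the series" means these compounds.

Compound 1 `CCC(=O)N1N=C(C)CC1c1cc(Br)ccc1O`: "not active" (no number reported)
Compound 2 `CCC(=O)N1N=C(C)CC1c1cc(Br)cc(Br)c1O`: 41400 nM

Only these two compounds have been tested in a functional assay on HepG2 cells (Homo sapiens) for cytotoxicity, read by MTT assay, with a stated time of 48 h; a lower number here means a stronger inhibitor, a higher number a weaker inhibitor. There, compound 1 was recorded as "not active" (no number reported), so it stands without a single number and offers no exact starting point. Compound 2 gives 41400 nM, the only numerical result available in this small set.

Compound 3 `C=CCN(CC=C)CC(=O)N1N=C(C)CC1c1cc(Br)ccc1O` has not yet been measured. The structural change is diallylamino in place of methyl on a saturated chain carbon bound to a carbonyl carbon, with diallylamino in place of methyl on a saturated chain carbon bound to a carbonyl carbon. Among the measured compounds shown here, no measured step shows what such a change does, and the missing number for compound 1 means that the size of the step cannot be calculated from the data. A modest step towards stronger inhibition in this assay is nevertheless expected, enough to yield a measurable number, although a second result without a number remains possible. The scale of that expectation rests on compound 2 at 41400 nM. Compound 3 is estimated at 40000 nM, with an expected range from 13000 nM to 120000 nM.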

Compound 3, half-maximal inhibitory concentration: 7870 nM
Compound 3: middle estimate off by 5.1-fold (0.71 log units), on the high side; measured number below the stated range.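

In this assay, among the compounds shown here, compound 3 gives 7870 nM, but compound 1 carries no number, and no step from compound 1 to compound 3 can be read. The compounds shown leave open how large the change from methyl to diallylamino is in this assay. Nothing measured here offers an explanation for the result.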